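A Fluoro Substituent Added to Compound 3

The source may hold more compounds than are shown below. What is called first, only, known or untested is meant among the compounds shown, and "the series" means these compounds.

Of the compounds shown here, three have so far been measured in an assay on CHO cells for displacement of a labelled ligand from adenosine receptor A1 (Homo sapiens), read by scintillation counting, with a stated time of 60 min, tested at 10 uM; on this read-out higher numbers stand for more inhibition at the one concentration tested (going by the name of the read-out) and lower numbers for less inhibition. Compound 1, `N=c1oc2ccc(Br)cc2cc1C(=O)NCC(O)CO`, gives 11%. Compound 2, `COc1cccc2cc(C(=O)NCC(=O)O)c(=O)oc12`, gives 27%. Compound 3, `COc1cccc2cc(C(=O)Nc3c(C#N)ncn3-c3ccccc3)c(=N)oc12`, gives 33%, the highest of the three numbers. Its number lies a few points above that of compound 2, a gap that is within the usual scatter, so these two cannot be ordered against each other; against compound 1 the gap is wider and beyond the scatter, so compound 3 does stand clearly above compound 1.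

Compound 4, `COc1cccc2cc(C(=O)Nc3c(C#N)ncn3-c3ccc(F)cc3)c(=N)oc12`, has not yet been measured. It differs from compound 3 in one place: fluoro in place of hydrogen on an aromatic carbon. Going by the values given here, no measured pair in this set shows a change of this kind, so there is no measured step on which to rest an expectation of its size. The expected step of a number 2 percentage points higher from compound 3 to compound 4 (within the scatter) is therefore small, not beyond the scatter, and of no settled direction. Compound 4 is estimated to give 35% in this assay, with a range from 15% to 55%.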

Compound 4, a percentage reported as inhibition, at one concentration (the size of the read-out at that concentration, not a potency): 46%
Compound 4: the middle estimate sits 11 percentage points below what was measured, within the range that was stated.
By their numbers in this assay, from the lowest: compound 1; then compounds 2 and 3 (each within the scatter of the next); then compound 4.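

Fluoro in place of hydrogen on an aromatic carbon, para to a large group, comes with a number 13 percentage points higher from compound 3 to compound 4 (beyond the scatter) in this assay. Going by these compounds alone, the earlier compounds offered no step between neighbours, so this is the first sign in the set that a change at this place on the phenyl ring can move the number beyond the scatter, and that a single fluorine, with no ring and no hydrogen-bond donors or acceptors of its own, is enough to do so. Nothing available here bears on why the number moves with this change.

On these data alone, whether the gain belongs to fluoro itself or would also come with another group at this place, such as chloro, methoxy or an amine, stays open, as does whether fluoro on another carbon of the same ring would give a similar step. As far as these compounds go, it is also open how far the step would hold at other concentrations, since each number is a percentage at one concentration and not a potency.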